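The compounds below may be only part of what the source reports. "The series", "measured", "known", "first", "only" and "open" are said of these compounds alone.

In an assay on HEK293 cells for agonist activity at transient receptor potential cation channel subfamily M member 8 (Homo sapiens), read by fluorescence and calcium flux, with a stated time of 15 min (a lower number here means that less compound is needed, a higher number that more compound is needed for the effect), compound 1 `CCN(Cc1cccs1)C(=O)COc1ccc(C)cc1` gives 8 nM, the lowest of the three numbers recorded. Compound 2 `Cc1ccc(OCC(=O)N(Cc2cccs2)c2ccn(C)n2)cc1` gives 855 nM and compound 3 `CCN(Cc1cccnc1)C(=O)COc1ccc(C)cc1` gives 15400 nM; from compound 1 the nearest step is a 110-fold higher number from compound 1 to compound 2 (2.03 log units; beyond the scatter) and the furthest is a 1900-fold higher number from compound 1 to compound 3 (3.28 log units; beyond the scatter). Compound 4 `CCCc1ccc(OCC(=O)N(CC)Cc2cccs2)cc1` differs from compound 1 by ethyl in place of hydrogen on a saturated chain carbon bound to an aromatic carbon, which read one bond further out is methyl to propyl. Among the compounds with values here, both measured steps alter groups on the amide-type nitrogen and leave the methyl-bearing ring untouched, so neither bears on this change, and no step of the present kind is available. Within the data shown here, with no precedent, the expected step of a 1.9-fold higher number from compound 1 to compound 4 (0.27 log units; within the scatter) is small, its direction not fixed beyond the scatter. Compound 4 is therefore estimated at 15 nM in this assay, within 3 nM to 80 nM.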

Compound 4, half-maximal effective concentration: 1810 nM
Estimate against measurement, compound 4: 120-fold (2.08 log units) below; the measured number lies above the stated range.
By their numbers in this assay, from the lowest: compound 1; then compound 2; then compound 4; then compound 3.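

In this assay, the methyl end of compound 1 proves highly sensitive: ethyl in place of hydrogen on a saturated chain carbon bound to an aromatic carbon gives a 230-fold higher number from compound 1 to compound 4 (2.35 log units; beyond the scatter) and so shows that large steps are not confined to changes around the amide-type nitrogen. A small addition of carbon with no donor or acceptor is enough for a step of this size. Nothing available accounts for this step.

As far as these compounds go, whether a chlorine atom or a methoxy group at this place would stay close to compound 1 remains open. So does whether propyl would give a similar step with the nitrogen groups of compound 2 or the pyridin-3-yl group of compound 3.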